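Amino in Place of Chloro: Three Measured, One Expected

The source may hold more compounds than are shown below. What is called first, only, known or untested is meant among the compounds shown, and "the series" means these compounds.

Three compounds sharing a common core carry a chloromethyl-substituted benzyl group and differ in how that group is attached and in one substituent on the core. Compound 3 `ClCc1ccc(Cn2cnc3c(Cl)nc(Cl)nc32)cc1` and compound 1 `Nc1nc(Cl)c2ncn(Cc3ccc(CCl)cc3)c2n1` form one matched pair. Compound 2 `ClCc1cccc(Cn2cnc3c(Cl)nc(Cl)nc32)c1` is built from the same atoms as compound 3, joined differently; the difference between the two cores is not broken down here.

In a functional assay on BT-549 cells (Homo sapiens) for cytotoxicity, read by sulforhodamine B assay, with a stated time of 48 h (on this read-out lower numbers stand for higher toxicity in this test and higher numbers for lower toxicity in this test), compound 3 gives 56200 nM and compound 1 gives 69200 nM. The change between them is amino in place of chloro on an aromatic carbon and it produced a 1.2-fold higher number from compound 3 to compound 1 (0.09 log units; within the scatter). Compound 2 gives 6160 nM in this assay, the lowest of the three numbers and beyond the scatter from both others, so among the measured compounds it is the most toxic in this test.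

Compound 4 `Nc1nc(Cl)c2ncn(Cc3cccc(CCl)c3)c2n1` has not yet been measured. It relates to compound 2 through (amino in place of chloro on an aromatic carbon), the same change, amino in place of chloro on an aromatic carbon, that turned compound 3 into compound 1, with the surroundings of the place described in identical words. The estimate for compound 4 rests on that single precedent, which gave a 1.2-fold higher number from compound 3 to compound 1 (0.09 log units; within the scatter). For compound 4 the expected step is therefore small: a 1.2-fold higher number from compound 2 to compound 4 (0.09 log units; within the scatter). On that basis compound 4 is expected to give 7500 nM in this assay, most likely between 3000 nM and 20000 nM.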

Compound 4, concentration lethal to 50% of the cells: 58900 nM
The estimate for compound 4 lay 7.9-fold (0.90 log units) below the measured number, and the stated range ends below it.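

In this assay, amino in place of chloro on an aromatic carbon, between two ring nitrogen atoms, gave a 9.6-fold higher number from compound 2 to compound 4 (0.98 log units; beyond the scatter), so on this core the change goes with lower toxicity in this test. The step seen on the other core did not carry over, and the same change gave clearly different results on the two cores: the same change on two cores in this assay, a 1.2-fold higher number (0.09 log units; within the scatter) from compound 3 to compound 1 and a 9.6-fold higher number (0.98 log units; beyond the scatter) from compound 2 to compound 4, 7.8-fold (0.89 log units) apart, beyond the scatter of two such steps. This shows that, for these two pairs, a step measured on one core was a poor guide to the step on the other, but with a single pair on each core it does not show what sets the difference or how the change would behave on any further core.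

The compounds shown leave open whether a methylamino or a methoxy group at the same place would follow the small step to compound 1 or the large step to compound 4. They also leave open what part the chloromethyl group plays in these numbers, since a hydroxymethyl or a plain methyl group in its place on either core would be needed to tell whether the difference between the two steps persists.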